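The compounds below may be only part of what the source reports. "The series", "measured", "known", "first", "only" and "open" are said of these compounds alone.

Measured so far:
- compound 1, `CCCCOC(=O)C1=C(S[C@@H]2CN[C@H](C(=O)Nc3cccc(C(=O)OCCCC)c3)C2)[C@H](C)[C@@H]2[C@@H]([C@@H](C)O)C(=O)N12`: > 95%
- compound 2, `CCC(CC)C(=O)OCOC(=O)C1=C(S[C@@H]2CN[C@H](C(=O)Nc3cccc(C(=O)O)c3)C2)[C@H](C)[C@@H]2[C@@H]([C@@H](C)O)C(=O)N12`: > 95%
- compound 3, `CCOC(=O)C1=C(S[C@H]2C[C@@H](C(=O)Nc3cccc(C(=O)OCC)c3)N(C(=O)OCc3oc(=O)oc3C)C2)[C@H](C)[C@@H]2[C@@H]([C@@H](C)O)C(=O)N12`: > 95%

Working notes on the series. In a physicochemical assay for metabolic stability, read by LC-MS, in phosphate buffer, with a stated time of 3 h, at pH 7.4, tested at 50 uM (a higher number here means that more of the compound is left, a lower number that less of the compound is left), compound 1 gives > 95%, which is a limit of the assay and not a number. In this assay compound 2 gives > 95%, again a limit and not a number. In this assay compound 3 gives > 95%, also a limit. Compound 2 therefore stands where every value shown stands so far: at the limit of > 95% in this assay, at which 3 of the 3 values shown sit. Within the data shown here, no step between measured compounds can be sized, since each pair sits at the same limit and the values only show that none of the three falls below it.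

The next compound is compound 4, `CCOC(=O)C1=C(S[C@@H]2CN[C@H](C(=O)Nc3cccc(C(=O)O)c3)C2)[C@H](C)[C@@H]2[C@@H]([C@@H](C)O)C(=O)N12`. It differs from compound 2 in one place: methyl in place of ((pentan-3-yl)carbonyl)oxy on a saturated chain carbon bound to an oxygen next to a carbonyl group. Among the measured compounds shown here, no measured step covers this change, so the expectation rests on the three values above. Nothing in them suggests a step in this assay beyond the scatter in either direction; compound 1, compound 2 and compound 3 all sit at the limit. For compound 4 the estimate is 94%, expected to sit at or just under the limit, meaning an expected step of a number at least 1 percentage points lower from compound 2 to compound 4 (that floor lies within the scatter).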

Compound 4, percent of the compound remaining: > 95%
Compound 4: a limit, no number; the forecaster's own chance of this, stated with the estimate: 60%; middle value at least 1 percentage points away from the limit.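

In this assay compound 4 gives > 95%, a limit and not a number. No step from compound 2 to compound 4 can be read, because both sit at the same limit: the limit of > 95% in this assay, at which 4 of the 4 values shown sit.

The compounds shown leave open whether the groups that differ among them have any effect in this assay.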